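Replacing piperidin-1-yl in a series stuck at a limit

This account rests on a few compounds, and the source may have more. Where it says the series, first, only, none or still open, it means among the compounds named here.

Measured in a functional assay on Jurkat cells (Homo sapiens) for inhibition, read by CCK-8 assay, with a stated time of 48 h; a higher number here means a weaker inhibitor of growth, a lower number a stronger inhibitor of growth:
- Compound 1 `Cc1ccccc1Nc1nc(Nc2ccccc2)ncc1Cl`: > 100000 nM
- Compound 2 `Cc1ccc(Nc2ncc(Cl)c(Nc3ccccc3C)n2)cc1`: > 100000 nM
- Compound 3 `Cc1ccccc1Nc1nc(Nc2ccc(N3CCCCC3)cc2)ncc1Cl`: > 100000 nM

Not yet measured: compound 4 `Cc1ccccc1Nc1nc(Nc2ccc(N3CCCN(C)CC3)cc2)ncc1Cl`.

All three entries are limits of the assay, not numbers. Compound 3 stands at > 100000 nM in this assay, which is a limit. Its rank among the three cannot be read, since the whole set shares (the limit of > 100000 nM in this assay, at which 3 of the 3 values shown sit).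

The next step puts 4-methyl-1,4-diazepan-1-yl in place of piperidin-1-yl on an aromatic carbon.

The closest evidence is the pair of steps that brought piperidin-1-yl onto this position, a step that the two limits leave unreadable from compound 1 to compound 3 and a step that the two limits leave unreadable from compound 2 to compound 3. The methyl step, a step that the two limits leave unreadable from compound 1 to compound 2, is no more informative. None of these steps has a readable size, so the data offer no measured guide to the size of the next one.

Compound 4 may well stay at the same limit. If it gives a number, that number can only be expected on the stronger side of the limit held by compound 3, so any expected move is toward stronger growth inhibition. The expected change is an at least 2.5-fold lower number from compound 3 to compound 4 (0.39 log units; beyond the scatter), and this is a loose estimate. For compound 4 the estimated value is 40000 nM, with an expected range from 6000 nM to 100000 nM.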

Compound 4, concentration for 50% growth inhibition: 11300 nM
Estimate against measurement, compound 4: 3.5-fold (0.55 log units) above; the measured number falls inside the stated range.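

In this assay, this place on the aromatic ring turns out to be able to change growth inhibition: an at least 8.8-fold lower number from compound 3 to compound 4 (0.94 log units; beyond the scatter) follows when 4-methyl-1,4-diazepan-1-yl takes the place of piperidin-1-yl. The new group gives the same kind of move against methyl, an at least 8.8-fold lower number from compound 2 to compound 4 (0.94 log units; beyond the scatter), and against hydrogen, an at least 8.8-fold lower number from compound 1 to compound 4 (0.94 log units; beyond the scatter), while the steps among compounds 1, 2 and 3 cannot be read. Compound 4 is thus the only compound shown with a measured number, and a ring on this carbon is not enough in itself, as compound 3 carries one and stays with the others at a limit: the limit of > 100000 nM in this assay, at which 3 of the 4 values shown sit.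

The change swaps a six-membered ring with one nitrogen for a seven-membered ring with two, one of them bearing a methyl, so the compounds shown cannot say which of these differences matters. As far as these compounds go, that question stays open for groups such as 4-methylpiperazin-1-yl, which keeps the second nitrogen and its methyl in a six-membered ring, and 1,4-diazepan-1-yl, which keeps the seven-membered ring without the methyl.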